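This account rests on a few compounds, and the source may have more. Where it says the series, first, only, none or still open, it means among the compounds named here.

In a functional assay on SW480 cells (Homo sapiens) for antiproliferative activity, read by MTT assay, with a stated time of 48 h (a lower number here means a stronger inhibitor, a higher number a weaker inhibitor), compound 1 `CC(C)=CCC[C@]1(C)/C=C/[C@@H](OC(=O)C=C(C)C)[C@](C)(O)/C=C/C(=O)/C(CN(C)C)=C\C1` gives 480 nM, and compound 2 `COCOC/C1=C/C[C@](C)(CCC=C(C)C)/C=C/[C@@H](OC(=O)C=C(C)C)[C@](C)(O)/C=C/C1=O` gives 3710 nM, the higher of the two numbers. Compound 3 `CC(C)=CCC[C@]1(C)/C=C/[C@@H](OC(=O)C=C(C)C)[C@](C)(O)/C=C/C(=O)/C(C(=O)N(C(C)C)C(C)C)=C\C1` has diisopropylcarbamoyl in place of (methoxymethoxy)methyl on a double-bonded ring carbon. Going by the values given here, the only measured step, a 7.7-fold higher number from compound 1 to compound 2 (0.89 log units; beyond the scatter), is modest and swaps dimethylamino for methoxymethoxy on a saturated chain carbon bound to a double-bonded ring carbon. Among the compounds with values here, no carbamoyl compound has been measured, and compound 3 has no dimethylamino group, so only a small upward change is expected in this assay, a 1.3-fold higher number from compound 2 to compound 3 (0.13 log units; within the scatter). The estimated value for compound 3 is 5000 nM, with an expected range of 1500 nM to 16000 nM.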

Compound 3, half-maximal inhibitory concentration: 16000 nM
Compound 3: the middle estimate sits 3.2-fold (0.51 log units) below what was measured, within the range that was stated.
By their numbers in this assay, from the lowest: compound 1; then compound 2; then compound 3.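

In this assay, diisopropylcarbamoyl on the double-bonded ring carbon gives a 4.3-fold higher number from compound 2 to compound 3 (0.63 log units; beyond the scatter) and, against (dimethylamino)methyl, a 33-fold higher number from compound 1 to compound 3 (1.52 log units; beyond the scatter). This place therefore still separates compounds that lack the dimethylamino group, and among these three groups (dimethylamino)methyl has the lowest number and diisopropylcarbamoyl the highest. Nothing available accounts for this order. As far as these compounds go, it remains open whether a smaller amide, such as dimethylcarbamoyl, would shift the number as far as diisopropylcarbamoyl does. Whether another amine, such as (diethylamino)methyl, or a carboxylic acid would fall nearer compound 1 is also unresolved.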